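Chloro for Hydrogen: Expected Cell Tolerance of Compound 4

The source may report more compounds than this note shows. Statements on the series, on what has been measured and on what is new or still open speak of the compounds shown alone.

Of the compounds shown here, three built on one shared core have been tested in an ADME assay on MDCK cells (Canis lupus familiaris) for cytotoxicity, read by CellTiter-Glo, with a stated time of 40 h; a higher number here means that more compound is tolerated, a lower number that less compound is tolerated. Compound 1 `CCCc1c(Cl)c(OC)c(Cl)c(O)c1Oc1c(Cl)c(O)c(Cl)c2c1C(=O)O[C@@H]2CC` reaches only a limit of the assay, giving > 50000 nM. Compound 2 `CCCc1c(Cl)c(OC)cc(O)c1Oc1c(Cl)c(O)c(Cl)c2c1C(=O)O[C@@H]2CC` likewise stops at a limit, giving > 50000 nM. Compound 3 `CCCc1cc(O)cc(OC)c1Oc1c(Cl)c(O)c(Cl)c2c1C(=O)O[C@@H]2CC` also returns a limit, giving > 100000 nM. Compound 2 and compound 1 differ by chloro in place of hydrogen on an aromatic carbon, and the step that the two limits leave unreadable from compound 2 to compound 1 cannot be sized since both values sit at the limit of > 50000 nM in this assay, at which 2 of the 3 values shown sit. How the core of compound 3 differs from the core of compound 2 is not broken down here. Compound 4 `CCCc1cc(O)c(Cl)c(OC)c1Oc1c(Cl)c(O)c(Cl)c2c1C(=O)O[C@@H]2CC` arises from compound 3 by chloro in place of hydrogen on an aromatic carbon, the same kind of change, although here the place is not meta to a chloro group. Because compound 3 rests at the limit of > 100000 nM in this assay, at which 1 of the 3 values shown sits, the step of a number no higher from compound 3 to compound 4 (the limit leaves the size open) is expected to be small. Compound 4 is therefore estimated to give 100000 nM in this assay.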

Compound 4, half-maximal cytotoxic concentration: > 100000 nM
Compound 4 ended at the assay's limit (the forecaster's own chance of this, stated with the estimate: 85%); the middle value lies on the limit itself.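

Compound 3 and compound 4 both end at a limit of this assay, and the step between them cannot be read. The compounds shown leave open whether chloro in place of hydrogen changes cell tolerance at all.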